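The compounds below may be only part of what the source reports. "The series", "measured", "known", "first", "only" and "open" are said of these compounds alone.

Measured so far in a functional assay on 1321-N1 cells for agonist activity at P2Y purinoceptor 2 (Homo sapiens), read by scintillation counting and inositol phosphate accumulation; on this read-out higher numbers stand for an effect only at larger amounts of compound and lower numbers for an effect already at smaller amounts:
compound 1 `O=c1[nH]/c(=N\OCCCc2ccc([N+](=O)[O-])cc2)ccn1[C@@H]1O[C@H](COP(=O)(O)OP(=O)(O)OP(=O)(O)O)[C@@H](O)[C@H]1O` gives 458 nM;
compound 2 `O=c1[nH]/c(=N\OCCCc2ccsc2)ccn1[C@@H]1O[C@H](COP(=O)(O)OP(=O)(O)OP(=O)(O)O)[C@@H](O)[C@H]1O` gives 103 nM;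
compound 3 `C#CCCCO/N=c1/ccn([C@@H]2O[C@H](COP(=O)(O)OP(=O)(O)OP(=O)(O)O)[C@@H](O)[C@H]2O)c(=O)[nH]1` gives 168 nM.

Compound 3 stands second highest of the three; the nearer step is a 1.6-fold higher number from compound 2 to compound 3 (0.21 log units; within the scatter), and the further one is a 2.7-fold lower number from compound 1 to compound 3 (0.44 log units; beyond the scatter). Compound 4 `O=c1[nH]/c(=N\OCCCc2ccc3ccccc3c2)ccn1[C@@H]1O[C@H](COP(=O)(O)OP(=O)(O)OP(=O)(O)O)[C@@H](O)[C@H]1O` differs from compound 3 by naphthalen-2-yl in place of ethynyl on a saturated chain carbon, three bonds along the chain from an oxygen on an unsaturated carbon. The two aromatic replacements seen so far point in opposite directions: a 4.4-fold lower number from compound 1 to compound 2 (0.65 log units; beyond the scatter) and a 2.7-fold lower number from compound 1 to compound 3 (0.44 log units; beyond the scatter) show an aromatic ring doing worse than ethynyl in one case and about equally in the other. No bicyclic aromatic has been measured, so only a modest shift in this assay is expected for compound 4, with wide uncertainty: a 1.5-fold higher number from compound 3 to compound 4 (0.17 log units; within the scatter). Compound 4 is therefore estimated at 250 nM, in the range 80 nM to 800 nM.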

Compound 4, half-maximal effective concentration: 139 nM
Compound 4: middle estimate off by 1.8-fold (0.25 log units), on the high side; measured number inside the range.
By their numbers in this assay, from the lowest: compounds 2, 4 and 3 (each within the scatter of the next); then compound 1.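

In this assay the much larger naphthalen-2-yl, with its two six-membered aromatic rings, gives a number that cannot be told apart from the one for ethynyl (a 1.2-fold lower number from compound 3 to compound 4 (0.08 log units; within the scatter)) or for thiophen-3-yl (a 1.3-fold higher number from compound 2 to compound 4 (0.13 log units; within the scatter)). At this position, then, size alone does not separate compound 2, compound 3 and compound 4, while compound 1 with its 4-nitrophenyl stays apart (a 3.3-fold lower number from compound 1 to compound 4 (0.52 log units; beyond the scatter)). Nothing available explains that gap. Going by these compounds, whether unsubstituted phenyl would sit with compound 4 or with compound 1 remains open. So does the effect of an amine or a carboxylic acid at the end of the chain, or of a longer chain.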